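Piperidin-1-yl gives way to ((furan-2-yl)methyl)amino in compound 3

This account rests on a few compounds, and the source may have more. Where it says the series, first, only, none or still open, it means among the compounds named here.

Of the compounds shown here, three have been tested in an ADME assay on RAW264.7 cells (Mus musculus) for cytotoxicity, read by WST assay; on this read-out higher numbers stand for lower toxicity in this test and lower numbers for higher toxicity in this test: compound 1 (`CC(C)(C)OC(=O)N(Cc1ccco1)C(=O)c1ccc(CN2Cc3ccccc3S2(=O)=O)cc1`), compound 2 (`O=C(c1ccc(Cn2c(=O)c3ccccc3[s+]2[O-])cc1)N1CCCCC1`) and compound 3 (`O=C(c1ccc(Cn2oc3ccccc3c2=O)cc1)N1CCCCC1`). Compound 1 gives > 100000 nM as a limit of the assay and not a number. Compound 2 likewise gives > 100000 nM as a limit of the assay. Compound 3 gives 66200 nM and is the only one of the three with an actual number, the other two sitting at the limit of > 100000 nM in this assay, at which 2 of the 3 values shown sit, in the data.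

Compound 4 (`O=C(NCc1ccco1)c1ccc(Cn2oc3ccccc3c2=O)cc1`) has not yet been measured. It differs from compound 3 in one place: on a carbonyl carbon, ((furan-2-yl)methyl)amino stands in place of piperidin-1-yl (((furan-2-yl)methyl)amino in place of piperidin-1-yl on a carbonyl carbon). A five-membered aromatic ring with 1 hetero atom thus replaces a six-membered non-aromatic ring with 1 hetero atom.

Among the compounds with values here, no two measured compounds differ in just one place, so the data give no size for such a change. In this assay no shift beyond the usual scatter is expected, in either direction, and the expectation rests on compound 3 at 66200 nM as its starting point. The expected change is a 1.1-fold higher number from compound 3 to compound 4 (0.02 log units; within the scatter) and no more. For compound 4 the estimated value is 70000 nM with an expected range of 35000 nM to 120000 nM in this test.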

Compound 4, concentration lethal to 50% of the cells: > 100000 nM
Compound 4: a limit, no number; the forecaster's own chance of this, stated with the estimate: 35%; at least 1.4-fold (0.15 log units) between middle value and limit.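

In this assay, within the data shown here, the swap of piperidin-1-yl for ((furan-2-yl)methyl)amino on the carbonyl carbon gives the first step that can be read at this position: an at least 1.5-fold higher number from compound 3 to compound 4 (0.17 log units; that floor lies within the scatter). The swap brings in a five-membered aromatic ring and a hydrogen-bond donor, and the result shows that this exchange does not bring the number down in this test, although the floor of the step alone does not establish a real shift. The full size of the step cannot be read, because compound 4 gives a limit of the assay and not a number: the limit of > 100000 nM in this assay, at which 3 of the 4 values shown sit.

On these data alone, it remains open how far compound 4 lies from compound 3, and so whether the change goes beyond the usual scatter of the assay. Also open, as far as these compounds go, is how other groups on the same carbonyl carbon would read out, such as morpholin-4-yl, a simple dimethylamino group or a benzylamino group, and whether the furan ring or the amide hydrogen of ((furan-2-yl)methyl)amino matters more to the result.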